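The source may report more compounds than this note shows. Statements on the series, on what has been measured and on what is new or still open speak of the compounds shown alone.

Working notes on the series, read in a functional assay on CHO cells (Cricetulus griseus) for inhibition, read by MTT assay, with a stated time of 96 h; on this read-out higher numbers stand for weaker inhibition and lower numbers for stronger inhibition. Compound 2 (`COc1ccc2c(OC)ccc(C(=O)O[C@H](C(N)=O)C3(C)CO3)c2c1`) gives 6000 nM and compound 3 (`Cc1ccc(C(=O)O[C@@H](C(N)=O)C2(C)CO2)c2ccccc12`) gives 5000 nM, two numbers within the scatter of each other. Compound 1 (`C=C(C)[C@@H](OC(=O)c1ccc(OC)c2ccc(OC)cc12)C(N)=O`) reads > 100000 nM, which is a limit of the assay and not a number. Compound 2 therefore stands with compound 3, and the only other result available is that limit.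

Compound 4 (`COc1ccc2c(OC)ccc(C(=O)O[C@@H](C(N)=O)C3(C)CO3)c2c1`) is the next one to read against compound 2. The change is the two compounds have the same atoms and bonds; at least one stereo element is drawn with a configuration in one of them and without one in the other: 1 of 2 stereo elements differ; a stereocentre at a saturated chain carbon is drawn S in compound 2 and R in compound 4: a stereocentre at a saturated chain carbon is drawn S in compound 2 and R in compound 4, with the same atoms and bonds in both.

Among the compounds with values here, the one measured step is an at least 16-fold lower number from compound 1 to compound 2 (1.22 log units; beyond the scatter), which is large. It exchanges a group, however, and leaves open what a change of drawn configuration alone does. Within the data shown here, no measured step covers that kind of change, so the size of that large step does not carry over. In this assay no step beyond the scatter is expected, and no direction is favoured, so the estimate stays anchored on compound 2 at 6000 nM, with a wide range. The estimate amounts to a 1.2-fold higher number from compound 2 to compound 4 (0.07 log units; within the scatter). For compound 4 the expected value is 7000 nM, with an estimated range of 1800 nM to 30000 nM.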

Compound 4, half-maximal inhibitory concentration: 3000 nM
For compound 4 the middle estimate is 2.3-fold (0.37 log units) above the measured one; measured number inside the range.
By their numbers in this assay, from the lowest: compounds 4, 3 and 2 (each within the scatter of the next). At a limit, above all of these: compound 1.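

In this assay, a stereocentre at a saturated chain carbon drawn R instead of S gives a 2.0-fold lower number from compound 2 to compound 4 (0.30 log units; within the scatter), so this first reading of a change of configuration alone is not separated from the scatter. The exchange seen earlier now has a second reading with the opposite drawn configuration: 2-methyloxiran-2-yl in place of 1-methylethenyl gives an at least 33-fold lower number from compound 1 to compound 4 (1.52 log units; beyond the scatter), so with either configuration at this carbon, the compounds carrying 2-methyloxiran-2-yl stand well apart from the compound carrying 1-methylethenyl. For compound 1 the comparison rests on a limit, not a number: the limit of > 100000 nM in this assay, at which 1 of the 4 values shown sits.

As far as these compounds go, what the other stereo element contributes stays open, and any reading of the configuration step carries this reservation: the fact that one of compounds 2 and 4 is drawn with a defined configuration and the other without, at the place where they differ. Also open, from the compounds shown here alone, is how a carboxylic acid in place of the carbamoyl group, or 2-ethyloxiran-2-yl in place of 2-methyloxiran-2-yl, would read in this assay.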